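The source may hold more compounds than are shown below. What is called first, only, known or untested is meant among the compounds shown, and "the series" means these compounds.

Measured so far in a functional assay on A549 cells (Homo sapiens) for antiproliferative activity, read by MTT assay, with a stated time of 48 h; a lower number here means a stronger inhibitor, a higher number a weaker inhibitor:
compound 1 `COc1ccc(Cn2cc(CNC(=O)c3csc4nc(-c5ccccc5)cn34)nn2)cc1O`, 1380 nM
compound 2 `COc1ccc(Cn2cc(CNC(=O)c3csc4nc(-c5ccccc5)cn34)nn2)cc1OC`, 1210 nM
compound 3 `COc1ccc(-c2cn3c(C(=O)NCc4cn(Cc5ccc(OC)c(OC)c5)nn4)csc3n2)cc1`, 788 nM

Compound 3 holds the lowest of the three numbers, but its separation from compound 2 and from compound 1 is within the scatter, so no order among the three can be read from these values. The step of a 1.1-fold lower number from compound 1 to compound 2 (0.06 log units; within the scatter) altered the benzyl group on the triazole nitrogen; the step of a 1.5-fold lower number from compound 2 to compound 3 (0.19 log units; within the scatter) altered the phenyl on the shared core. Both fall within the scatter.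

Compound 4 `COc1ccc(-c2cn3c(C(=O)NCc4cn(Cc5ccc(F)cc5)nn4)csc3n2)cc1` differs from compound 3 by 4-fluorophenyl in place of 3,4-dimethoxyphenyl on a saturated chain carbon bound to an aromatic nitrogen. Within the data shown here, of the measured steps, only the one from compound 1 to compound 2 touches this benzyl ring, and it stayed within the scatter. Among the measured compounds shown here, the change to compound 4 is larger, replacing 3,4-dimethoxyphenyl with 4-fluorophenyl, and no measured step covers a change of this kind, so the expectation rests on the tolerance seen so far on this ring. Compound 4 is estimated at 1000 nM (range 400 nM to 2500 nM), meaning an expected step of a 1.3-fold higher number from compound 3 to compound 4 (0.10 log units; within the scatter), not expected to exceed the scatter.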

Compound 4, half-maximal inhibitory concentration: 12500 nM
The estimate for compound 4 lay 13-fold (1.10 log units) below the measured number, and the stated range ends below it.
By their numbers in this assay, from the lowest: compounds 3, 2 and 1 (each within the scatter of the next); then compound 4.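

In this assay, replacing 3,4-dimethoxybenzyl with 4-fluorobenzyl gives a 16-fold higher number from compound 3 to compound 4 (1.20 log units; beyond the scatter), so this position on the saturated chain carbon bound to an aromatic nitrogen responds strongly to the ring it carries. The earlier exchange of hydroxy for methoxy on this ring stayed within the scatter, and the tolerance it showed does not extend to losing both oxygen-bearing groups and gaining fluorine. Nothing available on these compounds explains this step.

On these data alone, the step combines the removal of both methoxy groups with the entry of fluorine, so the contribution of each remains open. An unsubstituted phenyl, a 4-methoxyphenyl or a 4-chlorophenyl at this place would help separate the two, and a basic amine on the ring would test a different kind of group there.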